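Phenyl in place of propyl on the amide nitrogen

This account rests on a few compounds, and the source may have more. Where it says the series, first, only, none or still open, it means among the compounds named here.

Compound 2 `C=CC1=C(C(=O)NCCC)C(c2ccc(OC)c(OC)c2)OC1` is tested in a functional assay on HeLa cells (Homo sapiens) for cytotoxicity, read by MTT assay, with a stated time of 24 h; on this read-out lower numbers stand for stronger inhibition and higher numbers for weaker inhibition. In this read-out compound 2 gives only a limit of the assay, > 100000 nM. Compound 1 `C=CC1=C(C(=O)NCc2ccccc2)C(c2ccc(OC)c(OC)c2)OC1` likewise gives only a limit in this assay, > 100000 nM. Compound 3 `C=CC1=C(C(=O)NCCC)C(c2ccc(OC)cc2)OC1` gives 14000 nM in this assay. The step that the two limits leave unreadable from compound 1 to compound 2 cannot be read because both of its ends sit at the limit (the limit of > 100000 nM in this assay, at which 2 of the 3 values shown sit); the step of an at least 7.1-fold lower number from compound 2 to compound 3 (0.85 log units; beyond the scatter) is at least modest, but it concerns a methoxy group on the aromatic ring rather than the substituent on the amide nitrogen. Compound 4 `C=CC1=C(C(=O)Nc2ccccc2)C(c2ccc(OC)c(OC)c2)OC1` differs from compound 2 in one place: phenyl in place of propyl on an amide-type nitrogen. For the measured compounds named here, no measured step of this kind exists among the three compounds, and the two variants of the amide substituent seen so far, compound 1 and compound 2, both sit at the limit (the limit of > 100000 nM in this assay, at which 2 of the 3 values shown sit). The step that the limit leaves unreadable from compound 2 to compound 4 is therefore expected to remain unreadable. Compound 4 is estimated at 150000 nM, within 30000 nM to 600000 nM, most likely reported again only as a limit.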

Compound 4, half-maximal inhibitory concentration: 5030 nM
Compound 4: middle estimate off by 30-fold (1.47 log units), on the high side; the measured number lies below the stated range.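

In this assay, compound 4 shows that the substituent on the amide nitrogen can matter, with phenyl in place of propyl giving an at least 19-fold lower number from compound 2 to compound 4 (1.29 log units; beyond the scatter). Phenyl in place of benzyl gives an at least 19-fold lower number from compound 1 to compound 4 (1.29 log units; beyond the scatter), so among these compounds a phenyl group alone does not suffice: compound 1 also carries one, but on a saturated chain carbon rather than on the amide-type nitrogen. The step between compound 1 and compound 2 cannot be read, and the two new steps give only minimum sizes, as each starts from a limit: the limit of > 100000 nM in this assay, at which 2 of the 4 values shown sit.

As far as these compounds go, it remains open whether the change to anilino and the replacement of methoxy by hydrogen would add up in one compound. From the compounds shown here alone, it is also open whether a cyclohexyl or pyridyl group on the amide nitrogen would behave like phenyl.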